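The source may hold more compounds than are shown below. What is called first, only, known or untested is meant among the compounds shown, and "the series" means these compounds.

For the measured compounds named here, in a physicochemical assay for lipophilicity, at pH 7.4 (a higher number here means a more lipophilic compound, a lower number a more polar compound), compound 1 (`Cc1c(Sc2ccc(Cl)cc2)c2cc(-c3ccccc3)ccc2n1CC(=O)O`) gives 3.7, the higher of the two numbers so far. Compound 2 (`COc1ccc(Sc2c(C)n(CC(=O)O)c3ccc(C)cc23)cc1`) gives 1, a gap beyond the scatter. Compound 3 (`Cc1c(Sc2ccc(Cl)cc2)c2cc(F)ccc2n1CC(=O)O`) differs from compound 1 in one place: fluoro in place of phenyl on an aromatic carbon. This puts fluoro in place of phenyl on an aromatic carbon of the shared core, so one whole ring is lost. Going by the values given here, no measured pair isolates this change, so the expectation rests on the structural change itself, with compound 1 at 3.7 as the starting point. Compound 2, at 1, differs from compound 3 in more than one place and serves only as a rough lower guide. The estimated change in this assay is a number 1.80 log units lower from compound 1 to compound 3 (beyond the scatter), expected to be downward and beyond the scatter. Compound 3 is estimated at 1.9, with an expected range of 1.3 to 2.5.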

Compound 3, distribution coefficient: 1.8
Compound 3: the middle estimate sits 0.10 log units above what was measured, and the stated range covers the measured number.
By their numbers in this assay, from the lowest: compound 2; then compound 3; then compound 1.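

Fluoro in place of phenyl on this aromatic carbon of the shared core gives the first change in the series that can be read at a single place: in this assay the result is a number 1.90 log units lower from compound 1 to compound 3 (beyond the scatter), with the chloro-substituted sulfur-linked aryl group and the acetic acid chain unchanged. This position can therefore carry a large shift in this read-out when one six-membered aromatic ring of carbon only leaves and a single fluorine enters. Nothing available bears on the cause of this step.

A single step cannot apportion the shift between the loss of phenyl and the arrival of fluoro. Going by these compounds, how a hydrogen, a nitrile or an amine on this aromatic carbon would read against compound 1 and compound 3 remains open.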